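Swapping the amine-bearing piperidine ring on a shared core

The source may hold more compounds than are shown below. What is called first, only, known or untested is meant among the compounds shown, and "the series" means these compounds.

Measured compounds:
compound 1 `OCC(O)CNc1nc(Nc2ccccc2)nc2[nH]ccc12`: 82.4%
compound 2 `OCCNc1nc(Nc2ccccc2)nc2[nH]ccc12`: 86.9%
compound 3 `N[C@H]1CCCN(c2nc(Nc3cccc(Cl)c3)nc3[nH]ccc23)C1`: 38.3%

The three compounds were tested in an assay on isolated protein for inhibition of serine/threonine-protein kinase PAK 4 (Homo sapiens), read by filter binding, with a stated time of 20 min, tested at 2 uM; on this read-out higher numbers stand for more inhibition at the one concentration tested (going by the name of the read-out) and lower numbers for less inhibition. Compound 3 gives the lowest of the three numbers; the nearest is compound 1, and compound 2 stands furthest away, both beyond the scatter. Compound 4 `CC1(N)CCN(c2nc(Nc3cccc(Cl)c3)nc3[nH]ccc23)CC1` differs from compound 3 in one place: 4-amino-4-methylpiperidin-1-yl in place of 3-aminopiperidin-1-yl on an aromatic carbon. Going by the values given here, only one measured step exists, a number 4.5 percentage points higher from compound 1 to compound 2 (within the scatter), and it concerns a hydroxyalkylamino chain on the shared core rather than a piperidine ring, so it says little about the present change. Among the compounds with values here, no measured pair shows what moving the amine within the piperidine ring and adding a methyl does. With nothing to point either way, no step beyond the scatter is expected in this assay; the estimated step is a number 3.7 percentage points higher from compound 3 to compound 4 (within the scatter). Compound 4 is therefore expected to give about 42%, within a wide range from 18% to 68%.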

Compound 4, a percentage reported as inhibition, at one concentration (the size of the read-out at that concentration, not a potency): 35.5%
Estimate against measurement, compound 4: 6.5 percentage points above, within the range that was stated.
By their numbers in this assay, from the lowest: compounds 4 and 3 (each within the scatter of the next); then compounds 1 and 2 (each within the scatter of the next).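

In this assay, placing 4-amino-4-methylpiperidin-1-yl in place of 3-aminopiperidin-1-yl on this aromatic carbon gives a number 2.8 percentage points lower from compound 3 to compound 4 (within the scatter), the first step measured between two piperidine rings on the shared core. For these two compounds, then, the exchange leaves the reading within the scatter, even though the entering group has one more carbon and lacks the defined stereocentre of the group it replaces. Nothing available explains this outcome.

The shift of the amine around the ring and the added methyl arrive together in this single step, so neither can be read on its own. Also open, on these data alone, is how a carboxylic acid or a hydroxyl group in place of the ring's amine, or an aminomethyl group, would read in this assay at this position.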